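Working notes: from compound 1 to compound 4

This account rests on a few compounds, and the source may have more. Where it says the series, first, only, none or still open, it means among the compounds named here.

In an ADME assay on a cell-free system (plasma, Rattus norvegicus) for metabolic stability, read by LC-MS, with a stated time of 60 min, tested at 100 uM (on this read-out higher numbers stand for a more stable compound and lower numbers for a less stable compound), compound 1 (`Cc1c(OCCCCOCOc2ccc(C(=O)O)cc2)ccc(C(=O)CC2CCCC2)c1O`) gives 100%. Compound 2 (`COc1cc(C(=O)O)ccc1OCCCCOc1ccc(C(=O)CC(C)C)c(O)c1C`) gives 99%, which is within the scatter of the result for compound 1. Compound 3 (`Cc1c(OCCCCOc2ccc(F)c(C(=O)O)c2)ccc(C(=O)CC(C)(C)C)c1O`) gives 83%, which lies lower than compound 1 by more than the scatter.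

Compound 4 (`COc1ccc(C(=O)O)cc1OCCCCOc1ccc(C(=O)CC2CCCC2)c(O)c1C`) has not yet been measured. It has the same atoms as compound 1, joined differently: 5-carboxy-2-methoxyphenyl in place of (4-carboxyphenoxy)methyl on an oxygen on a saturated carbon. In words, 5-carboxy-2-methoxyphenyl stands in place of (4-carboxyphenoxy)methyl on an oxygen on a saturated carbon.

Within the data shown here, no measured pair differs in one place, so the size of this change has no direct precedent. The (4-carboxyphenoxy)methyl group is absent from compound 2 at 99% and from compound 3 at 83%, so its loss need not bring a large fall, although compound 3 shows that some fall is possible. In this assay the estimate is a number 7 percentage points lower from compound 1 to compound 4 (within the scatter), a small downward move expected to stay within the scatter. For compound 4 the expected value is 93%, with an estimated range of 78% to 100%.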

Compound 4, percent of the compound remaining: 103%
Estimate against measurement, compound 4: 10 percentage points below, and the stated range ends below it.
By their numbers in this assay, from the lowest: compound 3; then compounds 2, 1 and 4 (each within the scatter of the next).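

In this assay, among these compounds, the exchange of (4-carboxyphenoxy)methyl for 5-carboxy-2-methoxyphenyl on an oxygen on a saturated carbon gives a number 3 percentage points higher from compound 1 to compound 4 (within the scatter) and is the first step that differs in one place. It shows that, in this pair, the two groups cannot be told apart on this read-out, so this position accepts this exchange of one aromatic acid-bearing group for another of the same heavy-atom count with no separation between the two compounds. Nothing at hand explains the result.

As far as these compounds go, whether an amine or a longer chain on that same oxygen would also stay within the scatter of compound 1 remains open. Among the compounds shown here, compound 3 at 83% also cannot yet be tied to any one place in its structure, as no single-place step reaches it.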